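A Nitro Step Repeated on a Fluoro Core

This account rests on a few compounds, and the source may have more. Where it says the series, first, only, none or still open, it means among the compounds named here.

Three compounds have been measured in a physicochemical assay for lipophilicity, in phosphate buffer, measured as octanol-water partition, with a stated time of 24 h; on this read-out lower numbers stand for lower lipophilicity and higher numbers for higher lipophilicity:
Compound 1, `S=C(N/N=C/c1ccc(Oc2ccccc2)cc1)Nc1ccc(Br)cc1`, gives 6.38.
Compound 2, `O=[N+]([O-])c1ccc(Oc2ccc(/C=N/NC(=S)Nc3ccc(Br)cc3)cc2)cc1`, gives 5.68.
Compound 3, `Fc1ccc(NC(=S)N/N=C/c2ccc(Oc3ccccc3)cc2)cc1`, gives 5.09.

Compound 2 differs from compound 1 by nitro in place of hydrogen on an aromatic carbon, and that change brought a number 0.70 log units lower from compound 1 to compound 2 (beyond the scatter). The two cores differ by fluoro in place of bromo on an aromatic carbon, a change that brought a number 1.29 log units lower from compound 1 to compound 3 (beyond the scatter), so that compound 3 stands lowest of the three, with compound 2 nearest and compound 1 furthest.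

Compound 4, `O=[N+]([O-])c1ccc(Oc2ccc(/C=N/NC(=S)Nc3ccc(F)cc3)cc2)cc1`, has not yet been measured. It differs from compound 3 by nitro in place of hydrogen on an aromatic carbon; the place of the change is the same as in the step from compound 1 to compound 2, so this is the same change made on the core of compound 3. Going by the values given here, the step from compound 3 to compound 4 is expected to be a number 0.70 log units lower from compound 3 to compound 4 (beyond the scatter), close in size to a number 0.70 log units lower from compound 1 to compound 2 (beyond the scatter), because a number 0.70 log units lower from compound 1 to compound 2 (beyond the scatter) is the only measured example of this change here and nothing in the data points to a different outcome on the fluoro core. Compound 4 is therefore estimated at 4.39, expected to fall between 3.9 and 4.9.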

Compound 4, partition coefficient: 4.89
Beside the measured number, compound 4's estimate is 0.50 log units below it, within the range that was stated.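

In this assay the nitro change gave a number 0.20 log units lower from compound 3 to compound 4 (within the scatter) on the core of compound 3, against a number 0.70 log units lower from compound 1 to compound 2 (beyond the scatter) on the core of compound 1, so a step read beyond the scatter on one core was not repeated beyond the scatter on the other. Read the other way, fluoro in place of bromo gave a number 0.79 log units lower from compound 2 to compound 4 (beyond the scatter) and a number 1.29 log units lower from compound 1 to compound 3 (beyond the scatter) in the two available pairs, both beyond the scatter and both in the same direction. This single pair of cores does not show how the nitro change would behave on any further core, and nothing available here explains why the two cores differ in this way.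

The compounds shown carry only hydrogen or nitro at the changed place, so it remains open whether an amine or a carboxylic acid there would also give different steps on the two cores. From the compounds shown here alone, it also remains open how chloro in place of bromo would affect the step.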